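Cycloheptyl in Place of Difluorophenyl: Expected Cytotoxicity

The source may hold more compounds than are shown below. What is called first, only, known or untested is meant among the compounds shown, and "the series" means these compounds.

Of the compounds shown here, three have been measured in an ADME assay on TZM-b1 cells (Homo sapiens) for cytotoxicity, read by XTT assay, with a stated time of 3 days; a lower number here means that less compound is tolerated, a higher number that more compound is tolerated.
Compound 1, `Cc1nc(C(NC(=O)C(=O)Nc2ccc(Cl)cc2)C2CCCN2)sc1CO`, gives 12400 nM.
Compound 2, `Cc1ccc(NC(=O)C(=O)NC(c2nc(C)c(CO)s2)C2CCCCN2)cc1F`, gives > 88000 nM, which is a limit of this assay.
Compound 3, `Cc1nc(C(NC(=O)C(=O)Nc2ccc(F)c(F)c2)C2CCCCN2)sc1CO`, gives > 87000 nM, again a limit and not a number.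

Compound 3 therefore stands at the upper edge of what this assay reports. Within the data shown here, the only measured step, a step that the two limits leave unreadable from compound 2 to compound 3, cannot be read because the limit of > 87000 nM in this assay, at which 1 of the 3 values shown sits, and the limit of > 88000 nM in this assay, at which 1 of the 3 values shown sits, hold both of its ends.

Compound 4, `Cc1nc(C(NC(=O)C(=O)NC2CCCCCC2)C2CCCCN2)sc1CO`, differs from compound 3 by cycloheptyl in place of 3,4-difluorophenyl on an amide-type nitrogen. Among the measured compounds shown here, no measured step covers this change; compound 1, with its chlorophenyl group, is the only compound giving a number. Compound 4 is expected at 60000 nM, between 15000 nM and 90000 nM. The step of an at least 1.4-fold lower number from compound 3 to compound 4 (0.16 log units; that floor lies within the scatter) is expected to stay close to flat, though a limit at the starting point leaves it uncertain.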

Compound 4, half-maximal cytotoxic concentration: > 90000 nM
Compound 4 gave a limit, no number; the forecaster's own chance of this, stated with the estimate: 55%; at least 1.5-fold (0.17 log units) between middle value and limit.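

Compound 4 gives > 90000 nM, which is a limit and not a number, so its steps from compound 2 and from compound 3 cannot be read. The compounds shown leave open whether cycloheptyl, 3,4-difluorophenyl and 3-fluoro-4-methylphenyl differ in the concentration tolerated.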